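The source may hold more compounds than are shown below. What is called first, only, known or untested is meant among the compounds shown, and "the series" means these compounds.

Of the compounds shown here, three have been measured in a functional assay on HL-60 cells (Homo sapiens) for antiproliferative activity, read by XTT assay, with a stated time of 72 h; a lower number here means a stronger inhibitor, a higher number a weaker inhibitor. Compound 1 `C=C(C)CC[C@]1(C)C2=CCC[C@](C)(C[C@@H](O)c3ccoc3)[C@H]2CC[C@H]1C` gives 28700 nM, and compound 2 `C=C(C)CCC[C@]1(C)C2=CCC[C@](C)(C[C@H](O)c3ccoc3)[C@H]2CC[C@H]1C` gives 31200 nM; both carry a furan-3-yl group on the shared core. Compound 3 `C=C(C)CC[C@]1(C)C2=CCC[C@](C)(C[C@H](O)C3=CC(=O)OC3O)[C@H]2CC[C@H]1C` gives 3200 nM, the lowest of the three numbers, with compound 1 as its nearest neighbour and compound 2 furthest away, both beyond the scatter. Among the measured compounds shown here, the one single-point step measured so far is a 9.0-fold lower number from compound 1 to compound 3 (0.95 log units; beyond the scatter).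

Compound 4 `C=C(C)CC[C@]1(C)C2=CCC[C@](C)(C[C@H](O)c3ccoc3)[C@H]2CC[C@H]1C` is not yet measured. Compared with compound 3, the change is a group of 5 heavy atoms (4 carbon, 1 oxygen; one five-membered aromatic ring with 1 hetero atom) in place of a group of 7 heavy atoms (4 carbon, 3 oxygen; one five-membered non-aromatic ring with 1 hetero atom), on a saturated chain carbon bound to an oxygen on a saturated carbon and a saturated chain carbon

This is the reverse of the change from compound 1 to compound 3 in the group that is swapped, so the step measured there is the one that bears on it, and it argues for a rise of similar size. Compounds 1 and 2, which both carry the furan-3-yl group, sit close to each other. Compound 4 is therefore expected to show an 8.8-fold higher number from compound 3 to compound 4 (0.94 log units; beyond the scatter), landing at an estimated 28000 nM, with a range from 12000 nM to 65000 nM.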

Compound 4, half-maximal inhibitory concentration: 28700 nM
Compound 4: the middle estimate sits 1.0-fold (0.01 log units) below what was measured; measured number inside the range.
By their numbers in this assay, from the lowest: compound 3; then compounds 1, 4 and 2 (each within the scatter of the next).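

The group at this place clearly matters in this assay: with furan-3-yl in place of the non-aromatic ring, there is a 9.0-fold higher number from compound 3 to compound 4 (0.95 log units; beyond the scatter), so the earlier step from a furan-3-yl compound to compound 3 now has a matching step in the opposite direction. The drawn configuration at the chain stereocentre, by contrast, makes no visible difference, with no change at the digits printed from compound 1 to compound 4 (within the scatter), and this comparison isolates that one feature: the fact that compounds 1 and 4 differ only in the configuration as drawn. The other chain change also stays small, with a 1.1-fold lower number from compound 2 to compound 4 (0.04 log units; within the scatter) for 1-methylethenyl in place of 2-methylprop-2-en-1-yl.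

The compounds shown do not separate the contributions of the ring hydroxyl and the ring carbonyl in compound 3. From the compounds shown here alone, how an amine or a carboxylic acid at this place would read also remains open.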